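Methoxy for chloro on the carbonyl-side ring

The source may report more compounds than this note shows. Statements on the series, on what has been measured and on what is new or still open speak of the compounds shown alone.

Measured so far:
- compound 1, `Cc1ccc(S(=O)(=O)NCc2ccc(CNC(=O)c3cccc(Cl)c3)cc2)cc1`: 100 nM
- compound 2, `O=C(NCc1ccc(CNS(=O)(=O)c2ccccc2)cc1)c1cccc(Cl)c1`: 1000 nM
- compound 3, `Cc1ccc(C(=O)NCc2ccc(CNS(=O)(=O)c3ccccc3)cc2)cc1`: 100 nM

In an assay on MDA-MB-231 cells for binding affinity to C-X-C chemokine receptor type 4 (Homo sapiens), read by immunofluorescence and microscopy, with stated times of 10 min and 30 min (on this read-out higher numbers stand for an effect only at larger amounts of compound and lower numbers for an effect already at smaller amounts), compound 1 gives 100 nM and stands level with compound 3 at the digits printed, the two together the lowest of the three numbers; compound 2 sits furthest away, with a 10-fold higher number from compound 1 to compound 2 (1.00 log units; beyond the scatter) when hydrogen replaces methyl on an aromatic carbon. The other step recorded is a 10-fold lower number from compound 2 to compound 3 (1.00 log units; beyond the scatter) when 4-methylphenyl replaces 3-chlorophenyl on a carbonyl carbon.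

Compound 4, `COc1cccc(C(=O)NCc2ccc(CNS(=O)(=O)c3ccc(C)cc3)cc2)c1`, differs from compound 1 only by methoxy in place of chloro on an aromatic carbon. Neither measured step probes this change: one concerns the methyl on the sulfonyl-side ring, the other exchanges the whole ring on the carbonyl carbon together with its substituent. The data therefore give no direct guide for trading chloro for methoxy, and in this assay compound 4 is expected to stay near compound 1, with a 1.5-fold higher number from compound 1 to compound 4 (0.18 log units; within the scatter), a step not expected to exceed the scatter. Compound 4 is thus estimated at 150 nM, with a range from 40 nM to 600 nM.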

Compound 4, effective concentration (reported as EC, without a stated level of effect): 10 nM
For compound 4 the middle estimate is 15-fold (1.18 log units) above the measured one; measured number outside the range, below it.
By their numbers in this assay, from the lowest: compound 4; then compounds 1 and 3 (each within the scatter of the next); then compound 2.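

In this assay, the position on the carbonyl-side ring, meta to a large group, responds strongly to the identity of its substituent: methoxy in place of chloro gives a 10-fold lower number from compound 1 to compound 4 (1.00 log units; beyond the scatter). For the compounds shown here, the earlier compounds could not show this, as the only change on that side exchanged the whole ring together with its substituent, whereas here the ring stays and only the group on it differs. The step is also as large in size as the one seen at the methyl on the sulfonyl-side ring, a 10-fold higher number from compound 1 to compound 2 (1.00 log units; beyond the scatter), although it runs in the opposite direction, and nothing available explains why methoxy, with its 2 heavy atoms and 1 hydrogen-bond acceptor, gives this result where chloro does not.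

The compounds shown leave open how a hydroxy group, an ethoxy group or an amine would fare at this same position, and whether methoxy would give a similar result elsewhere on the ring. They also leave open whether the step carries over to the core of compound 2, which lacks the methyl on the sulfonyl-side ring and gives 1000 nM with chloro.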